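From 2,4-dichlorobenzyl to 1-(4-fluorophenyl)ethyl on the amide

A few compounds are considered here, and "the series" means these few. Any claim that something is new, unique, unknown or untested is made for them only; others in the source may bear on it.

Compound 1 `N[C@H]1CC[C@H](Nc2c(C(=O)NCc3ccc(F)cc3)nc(Br)c3cccnc23)CC1` gives 2000 nM in this series
Compound 2 `N[C@H]1CC[C@H](Nc2c(C(=O)NCc3ccc(Cl)cc3Cl)nc(Br)c3cccnc23)CC1` gives 6000 nM in this series

In a functional assay on SK-BR-3 cells (Homo sapiens) for cytotoxicity, read by MTT assay, with a stated time of 72 h (on this read-out higher numbers stand for weaker inhibition and lower numbers for stronger inhibition), compound 2 gives 6000 nM as the higher of the two numbers. Compound 3 `C[C@H](NC(=O)c1nc(Br)c2cccnc2c1N[C@H]1CC[C@H](N)CC1)c1ccc(F)cc1` carries 1-(4-fluorophenyl)ethyl in place of 2,4-dichlorobenzyl on an amide-type nitrogen. Among the measured compounds shown here, one measured step bears on this (a 3.0-fold higher number from compound 1 to compound 2 (0.48 log units; beyond the scatter)), modest and beyond the scatter, with the 4-fluorophenyl compound 1 at the lower number. For the measured compounds named here, no measured compound shows what the defined stereocentre adds. In this assay a somewhat smaller step toward a lower number is therefore expected (a 2.4-fold lower number from compound 2 to compound 3 (0.38 log units; beyond the scatter)). Compound 3 is estimated at 2500 nM (range 900 nM to 7000 nM).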

Compound 3, half-maximal inhibitory concentration: 9000 nM
Compound 3: middle estimate off by 3.6-fold (0.56 log units), on the low side; measured number above the stated range.
By their numbers in this assay, from the lowest: compound 1; then compounds 2 and 3 (each within the scatter of the next).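

In this assay, methyl in place of hydrogen on the saturated chain carbon bound to an amide-type nitrogen and an aromatic carbon brings a 4.5-fold higher number from compound 1 to compound 3 (0.65 log units; beyond the scatter), so this carbon affects the read-out even with the 4-fluorophenyl kept. The change from 2,4-dichlorobenzyl to 1-(4-fluorophenyl)ethyl brings a 1.5-fold higher number from compound 2 to compound 3 (0.18 log units; within the scatter), so these two groups cannot be told apart here. The compounds shown leave open how the opposite stereocentre, or an ethyl or hydroxymethyl on that carbon, would read. No supporting evidence accounts for the methyl step.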